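Ketoamide series: extending the isobutyl amide chain

The source may report more compounds than this note shows. Statements on the series, on what has been measured and on what is new or still open speak of the compounds shown alone.

Compound 1 `CCOC(=O)C(=O)C(CC)NC(=O)C(CC(C)C)NC(=O)OCc1ccccc1` gives 300000 nM in a functional assay for inhibition, with Rattus norvegicus as the target, at pH 7.35; a higher number here means a weaker inhibitor, a lower number a stronger inhibitor
Compound 2 `CCC(=O)C(=O)[C@H](CC)NC(=O)[C@H](CC(C)C)NC(=O)[C@H](CC(C)C)NC(=O)OCc1ccccc1` gives 40000 nM in this assay
Compound 3 `CCC(NC(=O)C(CC(C)C)NC(=O)OCc1ccccc1)C(=O)C(=O)NCC(C)C` gives 28000 nM in this assay

Compound 3 and compound 2 lie within the scatter of each other, and compound 1 stands well apart from both. Compound 4 `CCC(NC(=O)C(CC(C)C)NC(=O)OCc1ccccc1)C(=O)C(=O)NCCCc1ccccc1` carries phenethyl in place of isopropyl on a saturated chain carbon bound to an amide-type nitrogen, which also reads isobutylamino to (3-phenylpropyl)amino. Among the measured compounds shown here, one measured step touches this group, an 11-fold lower number from compound 1 to compound 3 (1.03 log units; beyond the scatter), and it was large. For the measured compounds named here, that step replaced ethoxy, however, and no measured step compares two amine chains. A smaller change toward a lower number is therefore expected in this assay. The expected step is a 2.0-fold lower number from compound 3 to compound 4 (0.30 log units; within the scatter). Compound 4 is estimated at 14000 nM, with an expected range of 4000 nM to 40000 nM.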

Compound 4, half-maximal inhibitory concentration: 100000 nM
Compound 4: the middle estimate sits 7.1-fold (0.85 log units) below what was measured, and the stated range ends below it.
By their numbers in this assay, from the lowest: compounds 3 and 2 (each within the scatter of the next); then compound 4; then compound 1.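

In this assay two amine chains can now be compared directly: phenethyl in place of isopropyl on a saturated chain carbon bound to an amide-type nitrogen gives a 3.6-fold higher number from compound 3 to compound 4 (0.55 log units; beyond the scatter) and so costs potency at this position. Replacing ethoxy still helps with the longer chain, with a 3.0-fold lower number from compound 1 to compound 4 (0.48 log units; beyond the scatter) against an 11-fold lower number from compound 1 to compound 3 (1.03 log units; beyond the scatter) for the isobutylamino group. No measurement here accounts for the loss.

As far as these compounds go, whether the loss comes with chain length or with the phenyl ring remains open. A plain n-pentyl chain, a benzyl group, or a chain ending in an amine or a carboxylic acid would help separate these.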